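The compounds below may be only part of what the source reports. "The series", "measured", "known", "first", "only" and "open" are said of these compounds alone.

Of the compounds shown here, three built on one shared core have been measured in a functional assay on NCI-H1975 cells (Homo sapiens) for antiproliferative activity, read by MTT assay, with a stated time of 72 h; on this read-out lower numbers stand for stronger inhibition and higher numbers for weaker inhibition. Compound 1 `COc1cc(F)c(NC(=O)c2ccncc2OC)cc1Nc1nccc(-c2cn(C)c3ccccc23)n1` gives 4120 nM, compound 2 `COc1cc(N(C)CCN(C)C)c(NC(=O)c2ccncc2OC)cc1Nc1nccc(-c2cn(C)c3ccccc23)n1` gives 1010 nM, and compound 3 `COc1cc(N(C)C)c(NC(=O)c2ccncc2OC)cc1Nc1nccc(-c2cn(C)c3ccccc23)n1` gives 12100 nM, which is the highest of the three numbers, beyond the scatter from both of the others. Every step among these three touches the same aromatic carbon: a 4.1-fold lower number from compound 1 to compound 2 (0.61 log units; beyond the scatter), a 2.9-fold higher number from compound 1 to compound 3 (0.47 log units; beyond the scatter), and a 12-fold higher number from compound 2 to compound 3 (1.08 log units; beyond the scatter). Compound 4 `COc1cc(N(C)C)c(NC(=O)c2ccncn2)cc1Nc1nccc(-c2cn(C)c3ccccc23)n1` alters a different part of the molecule: pyrimidin-4-yl in place of 3-methoxypyridin-4-yl on a carbonyl carbon. Among the compounds with values here, no measured step changes the ring on that carbonyl carbon, so none of the three known steps bears directly on this exchange, and the known data leave its effect open. With nothing to pull the number either way, the step from compound 3 to compound 4 in this assay is expected to stay within the scatter, as a 1.0-fold lower number from compound 3 to compound 4 (0.00 log units; within the scatter). Compound 4 is therefore estimated at 12000 nM in this assay, with a range from 4000 nM to 36000 nM.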

Compound 4, half-maximal inhibitory concentration: 1250 nM
Compound 4: middle estimate off by 9.6-fold (0.98 log units), on the high side, and the stated range ends above it.
By their numbers in this assay, from the lowest: compounds 2 and 4 (each within the scatter of the next); then compound 1; then compound 3.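

The ring on the carbonyl carbon matters in this assay: pyrimidin-4-yl in place of 3-methoxypyridin-4-yl gives a 9.7-fold lower number from compound 3 to compound 4 (0.99 log units; beyond the scatter). Within the data shown here, the earlier steps all touched one aromatic carbon, so this is the first sign that the other end of the molecule also moves the number, by a step of similar size to a 12-fold higher number from compound 2 to compound 3 (1.08 log units; beyond the scatter). No measurement here explains the change, which swaps the ring and removes the methoxy group in a single exchange.

The compounds shown leave open whether an unsubstituted pyridin-4-yl ring would give the same step, and so which part of the exchange carries it. Also open, from the compounds shown here alone, is whether pyrimidin-4-yl acts alike with fluoro or (2-(dimethylamino)ethyl)(methyl)amino on the aromatic carbon in place of dimethylamino, and what an amine on the ring would do.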